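Methoxy in place of fluoro on a shared aminoquinoline-free core

A few compounds are considered here, and "the series" means these few. Any claim that something is new, unique, unknown or untested is made for them only; others in the source may bear on it.

Measured compounds:
Compound 1, `CCCCNc1ccnc2cc(F)ccc12`, 1630 nM
Compound 2, `CN(C)CCNc1ccnc2cc(Cl)ccc12`, 3320 nM
Compound 3, `CN(C)CCNc1ccnc2cc(F)ccc12`, 1730 nM

In a functional assay on MCF7 cells (Homo sapiens) for cytotoxicity, read by sulforhodamine B assay, with a stated time of 48 h, in the presence of a further agent that is not named here (a lower number here means a stronger inhibitor of growth, a higher number a weaker inhibitor of growth), compound 3 gives 1730 nM, the second highest of the three numbers. Its nearest neighbour is compound 1, whose number sits a 1.1-fold higher number from compound 1 to compound 3 (0.03 log units; within the scatter) away, and its furthest is compound 2, which lies a 1.9-fold lower number from compound 2 to compound 3 (0.28 log units; within the scatter) apart. Both steps fall within the scatter, so the three measured compounds are indistinguishable on these numbers.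

Compound 4, `COc1ccc2c(NCCN(C)C)ccnc2c1`, has not yet been measured. It differs from compound 3 by methoxy in place of fluoro on an aromatic carbon. Among the measured compounds shown here, no measured pair exchanges fluoro for methoxy, so only indirect evidence bears on it: the swap of chloro for fluoro at the same position, a 1.9-fold lower number from compound 2 to compound 3 (0.28 log units; within the scatter), stayed within the scatter, and the change at the chain, a 1.1-fold higher number from compound 1 to compound 3 (0.03 log units; within the scatter), likewise. With substituents at this position showing no effect beyond the scatter so far, compound 4 is expected to give about 2000 nM in this assay, with a plausible range from 700 nM to 6000 nM, a step of a 1.2-fold higher number from compound 3 to compound 4 (0.06 log units; within the scatter) that is expected to remain within the scatter.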

Compound 4, concentration for 50% growth inhibition: 1820 nM
Compound 4: the middle estimate sits 1.1-fold (0.04 log units) above what was measured; the range from low to high includes it.
By their numbers in this assay, from the lowest: compounds 1, 3, 4 and 2 (each within the scatter of the next, the first and the last beyond it).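

Methoxy in place of fluoro on this aromatic carbon, a swap that brings in a hydrogen-bond acceptor, gives a 1.1-fold higher number from compound 3 to compound 4 (0.02 log units; within the scatter) in this assay. Methoxy in place of chloro gives a 1.8-fold lower number from compound 2 to compound 4 (0.26 log units; within the scatter), also within the scatter. With the dimethylamino chain held fixed, fluoro, chloro and methoxy at this position therefore cannot be told apart on these numbers, and adding an oxygen and a carbon in place of a halogen has shown no effect beyond the scatter.

On these data alone, whether an amine or a carboxylic acid on this aromatic carbon, or a longer chain on the oxygen in place of methoxy, would move the number beyond the scatter stays open. Nothing available here offers an explanation for this flat response at the position.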